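Notes on the step from compound 3 to compound 4

A few compounds are considered here, and "the series" means these few. Any claim that something is new, unique, unknown or untested is made for them only; others in the source may bear on it.

Compound 3 `C=CCc1cc(C(C)=O)c(O)cc1OCCCCC#N` gives 92% in an assay on isolated protein for inhibition of leukotriene B4 receptor 1 (Homo sapiens), tested at 10 uM (a lower number here means less inhibition, a higher number more inhibition at the concentration tested (going by the name of the read-out)), the highest of the three measured numbers. Compound 2 `CC(=O)c1cc(CC2CO2)c(OCCCCC#N)cc1O` gives 62% and compound 1 `CCCCCCc1cc(C(C)=O)c(O)cc1OCCCCC#N` gives 51%; the steps of a number 30 percentage points higher from compound 2 to compound 3 (beyond the scatter) and a number 41 percentage points higher from compound 1 to compound 3 (beyond the scatter) are both beyond the scatter, as is a number 11 percentage points higher from compound 1 to compound 2 (beyond the scatter). Compound 4 `C=CCc1cc(C(C)=O)c(O)cc1OCCCCCC(C)=O` differs from compound 3 by 2-oxopropyl in place of cyano on a saturated chain carbon, four bonds along the chain from an oxygen on an aromatic ring. Going by the values given here, all three measured steps alter the group on the saturated chain carbon bound to the aromatic carbon; none touches the chain end that changes here, so no measured step bears directly on this change. In the absence of such a step, no change beyond the scatter is expected for compound 4, and the estimated step is a number 10 percentage points lower from compound 3 to compound 4 (within the scatter). Compound 4 is therefore expected to give 82%, within 55% to 96%.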

Compound 4, a percentage reported as inhibition, at one concentration (the size of the read-out at that concentration, not a potency): 98%
Compound 4: the middle estimate sits 16 percentage points below what was measured; the measured number lies above the stated range.
By their numbers in this assay, from the lowest: compound 1; then compound 2; then compounds 3 and 4 (each within the scatter of the next).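

In this assay, going by these compounds alone, 2-oxopropyl in place of cyano gives a number 6 percentage points higher from compound 3 to compound 4 (within the scatter), the first measured change at this chain end, so the nitrile is not needed to keep the number high in this pair. Within the data shown here, with the allyl-bearing core of compound 3, either end group gives inhibition at the top of the series, and a single-concentration read-out gives no potency for either compound. Nothing available explains why the two end groups read alike.

Open, from the compounds shown here alone, is whether a carboxylic acid, an amine or a longer chain at this end would hold the number. Also open, going by these compounds, is whether the same exchange behaves alike with pentyl or oxiran-2-yl in place of vinyl.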